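The source may report more compounds than this note shows. Statements on the series, on what has been measured and on what is new or still open speak of the compounds shown alone.

In a functional assay on KB cells (Homo sapiens) for antiproliferative activity, read by MTT assay, with a stated time of 48 h (on this read-out lower numbers stand for stronger inhibition and higher numbers for weaker inhibition), compound 1 `Cn1cc(C2=C(c3nn(CCCn4cncn4)c4ncccc34)C(=O)NC2=O)c2ccccc21` gives > 100000 nM, which is a limit of the assay and not a number. Compound 1 therefore stands at the limit of > 100000 nM in this assay, at which 1 of the 3 values shown sits. Two relatives do return numbers: compound 2 `Cn1cc(C2=C(c3nn(CCCN4CCCCC4)c4ncccc34)C(=O)N(c3cccc4ccccc34)C2=O)c2ccccc21` gives 13400 nM, and compound 3 `CN(C)CCCn1nc(C2=C(c3cn(C)c4ccccc34)C(=O)N(c3ccccc3)C2=O)c2cccnc21` gives 14100 nM. Compound 4 `Cn1cc(C2=C(c3n[nH]c4ncccc34)C(=O)NC2=O)c2ccccc21` differs from compound 1 in one place hydrogen in place of 3-(1H-1,2,4-triazol-1-yl)propyl on an aromatic nitrogen: hydrogen stands in place of 3-(1H-1,2,4-triazol-1-yl)propyl on an aromatic nitrogen. Among the compounds with values here, no measured pair shows what this change does in this assay. A modest shift toward stronger inhibition is expected, or possibly none beyond the scatter. The expected move is an at least 2.5-fold lower number from compound 1 to compound 4 (0.39 log units; beyond the scatter). For compound 4 the estimated value is 40000 nM, with an expected range from 8000 nM to 100000 nM.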

Compound 4, half-maximal inhibitory concentration: 62000 nM
The estimate for compound 4 lay 1.6-fold (0.19 log units) below the measured number; the measured number falls inside the stated range.
By their numbers in this assay, from the lowest: compounds 2 and 3 (each within the scatter of the next); then compound 4. At a limit, above all of these: compound 1.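

Replacing the 3-(1H-1,2,4-triazol-1-yl)propyl group on this aromatic nitrogen with hydrogen gives compound 4 a real number in this assay, so this position now has a measured reference point. The change gives an at least 1.6-fold lower number from compound 1 to compound 4 (0.20 log units; that floor lies within the scatter). Its true size cannot be read because compound 1 sits at a limit, not at a number: the limit of > 100000 nM in this assay, at which 1 of the 4 values shown sits.

Still open, on these data alone, is whether the triazole or the propyl chain matters here. A propyl chain on the core of compound 1 ending in a morpholine or a carboxylic acid could separate the two.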